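From an Amino Group to a Methoxy Group

The source may report more compounds than this note shows. Statements on the series, on what has been measured and on what is new or still open speak of the compounds shown alone.

Two measured compounds frame this step. Compound 1 `CCCCCOC(=O)N1CCN(C(=O)[C@H](CCC(=O)O)NC(=O)c2cc(N3CCC(C(=O)NCC)CC3)nc(-c3ccccc3)n2)CC1` was tested in an ADME assay on microsomes from liver (Rattus norvegicus) for metabolic stability; a lower number here means that less of the compound is left, a higher number that more of the compound is left. In this assay compound 1 reaches only the limit of the assay, > 80%. Compound 2 `CCCCCOC(=O)N1CCN(C(=O)[C@H](CCC(=O)O)NC(=O)c2nc(-c3ccccc3)cc(N3CCC(CN)CC3)n2)CC1` is its companion. In this assay compound 2 likewise reaches the limit, > 80%. Compound 2 therefore stands at the limit together with compound 1: the limit of > 80% in this assay, at which 2 of the 2 values shown sit. Among the measured compounds shown here, no step between measured compounds is available, so the size of the change ahead cannot be read from neighbours.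

Compound 3 `CCCCCOC(=O)N1CCN(C(=O)[C@H](CCC(=O)O)NC(=O)c2nc(-c3ccccc3)cc(N3CCC(COC)CC3)n2)CC1` is the unmeasured one. It differs from compound 2 by methoxy in place of amino on a saturated chain carbon bound to a saturated ring carbon. With both known values at the limit, no shift beyond the usual scatter is expected, and the step from compound 2 to compound 3 is estimated as a step that the limit leaves unreadable from compound 2 to compound 3. Compound 3 is thus expected to come out at an estimated 85%, with a range from 70% to 97%.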

Compound 3, percent of the compound remaining: > 80%
Compound 3 gave a limit, no number (the forecaster's own chance of this, stated with the estimate: 65%); the middle value does not contradict the limit.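

Among the compounds shown here, compound 2 and compound 3 both give only a limit in this assay, not a number, so no step between them can be read. The compounds shown leave open whether aminomethyl and methoxymethyl differ at all in how much compound remains.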